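From 3-Methylphenyl to 4-Methoxyphenyl: An Expected Step

A few compounds are considered here, and "the series" means these few. Any claim that something is new, unique, unknown or untested is made for them only; others in the source may bear on it.

In a functional assay on MDA-MB-231 cells (Homo sapiens) for inhibition, read by CCK-8 assay, with a stated time of 48 h (on this read-out higher numbers stand for weaker inhibition of growth and lower numbers for stronger inhibition of growth), compound 1 `Cc1ccccc1Nc1nc(Nc2ccc(N3CCN(C)CC3)cn2)ncc1Cl` gives 7470 nM. Compound 2 `CN1CCN(c2ccc(Nc3ncc(Cl)c(Nc4ccccc4)n3)nc2)CC1` gives 37400 nM, and compound 3 `Cc1cccc(Nc2nc(Nc3ccc(N4CCN(C)CC4)cn3)ncc2Cl)c1` gives 5270 nM. Compound 3 therefore stands within the usual scatter of compound 1, as the step of a 1.4-fold lower number from compound 1 to compound 3 (0.15 log units; within the scatter) shows, and clearly apart from compound 2, with the step of a 7.1-fold lower number from compound 2 to compound 3 (0.85 log units; beyond the scatter).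

The next compound, compound 4 `COc1ccc(Nc2nc(Nc3ccc(N4CCN(C)CC4)cn3)ncc2Cl)cc1`, changes the group on the nitrogen: 4-methoxyphenyl in place of 3-methylphenyl on a nitrogen on an aromatic ring. In words, 4-methoxyphenyl comes in place of 3-methylphenyl on a nitrogen on an aromatic ring.

Within the data shown here, three measured steps bear on this. Removing the methyl from compound 1 cost a modest amount, a 5.0-fold higher number from compound 1 to compound 2 (0.70 log units; beyond the scatter), and adding a methyl gave a similar modest gain, a 7.1-fold lower number from compound 2 to compound 3 (0.85 log units; beyond the scatter). Changing where the methyl sits did not register, a 1.4-fold lower number from compound 1 to compound 3 (0.15 log units; within the scatter). These compounds suggest that a substituted group on that nitrogen matters more than the exact group, yet none of them carries a methoxy, so this remains a loose guide.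

No step beyond the scatter is expected, and the estimate is a 1.1-fold higher number from compound 3 to compound 4 (0.06 log units; within the scatter). For compound 4 the expected value is 6000 nM, with an estimated range from 2000 nM to 18000 nM.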

Compound 4, concentration for 50% growth inhibition: 8020 nM
Beside the measured number, compound 4's estimate is 1.3-fold (0.13 log units) below it, and the stated range covers the measured number.
By their numbers in this assay, from the lowest: compounds 3, 1 and 4 (each within the scatter of the next); then compound 2.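

In this assay, the group on this nitrogen can carry an oxygen without leaving the range set by the methyl compounds: the step to 4-methoxyphenyl from 3-methylphenyl is within the scatter, a 1.5-fold higher number from compound 3 to compound 4 (0.18 log units; within the scatter), and so is the step from 2-methylphenyl, a 1.1-fold higher number from compound 1 to compound 4 (0.03 log units; within the scatter). The gain over a ring with no substituent is therefore not confined to methyl, since methoxy in place of hydrogen also gives a step beyond the scatter, a 4.7-fold lower number from compound 2 to compound 4 (0.67 log units; beyond the scatter). No measurement at hand explains why methoxy and methyl read alike here or why either differs from hydrogen.

The change from compound 3 to compound 4 alters both the group and its place on the ring, so these compounds cannot separate the effect of swapping methyl for methoxy from the effect of moving it. On these data alone, it also remains open whether this tolerance extends to quite different groups on the same ring, such as an amine, a carboxylic acid or a longer chain like butoxy.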